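Shortening the acyl chain from compound 2 to compound 3

The compounds below may be only part of what the source reports. "The series", "measured", "known", "first", "only" and "open" are said of these compounds alone.

Compound 1, `CCCC(=O)c1ccc(OCCCCOc2ccc(F)c(C(=O)O)c2)c(C)c1O`: 74 nM
Compound 2, `CCC(=O)c1ccc(OCCCCOc2ccc(F)c(C(=O)O)c2)c(C)c1O`: 124 nM

In an assay on HEK293 cells for positive allosteric modulation of metabotropic glutamate receptor 2 (Rattus norvegicus), read by thallium flux, with a stated time of 2.5 min (a lower number here means that less compound is needed, a higher number that more compound is needed for the effect), compound 2 gives 124 nM. Compound 1 gives 74 nM, and the two lie within the scatter of each other. Compound 3 is `CC(=O)c1ccc(OCCCCOc2ccc(F)c(C(=O)O)c2)c(C)c1O` and differs from compound 2 by hydrogen in place of methyl on a saturated chain carbon bound to a carbonyl carbon. Among the compounds with values here, the only step that bears on it is the same cut one bond further out, a 1.7-fold higher number from compound 1 to compound 2 (0.22 log units; within the scatter), which stayed within the scatter. A shift of similar size is expected, so the estimated step is a 1.5-fold higher number from compound 2 to compound 3 (0.19 log units; within the scatter). Compound 3 is thus expected near 190 nM, within 80 nM to 450 nM.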

Compound 3, half-maximal effective concentration: 259 nM
The estimate for compound 3 lay 1.4-fold (0.13 log units) below the measured number; measured number inside the range.
By their numbers in this assay, from the lowest: compounds 1 and 2 (each within the scatter of the next); then compound 3.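

The step of a 2.1-fold higher number from compound 2 to compound 3 (0.32 log units; beyond the scatter) in this assay clears the scatter, which the same cut one bond further out did not. Taken over both cuts, the step of a 3.5-fold higher number from compound 1 to compound 3 (0.54 log units; beyond the scatter) is also beyond the scatter, so compound 3, with its acetyl group, stands apart from compound 1 and compound 2, which remain within the scatter of each other.

On these data alone, a longer chain, a branched chain or an amine at this saturated chain carbon remains open, and with it whether the number keeps moving with chain length. Nothing measured here accounts for these steps.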